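A Bulkier Carbamate Ester on a Shared Core

The source may report more compounds than this note shows. Statements on the series, on what has been measured and on what is new or still open speak of the compounds shown alone.

Compound 1 `CN(Cc1ccco1)C(=O)c1ccc(CN2C(=O)c3ccccc3S2(=O)=O)cc1`: in an ADME assay on RAW264.7 cells (Mus musculus) for cytotoxicity, read by WST assay (on this read-out higher numbers stand for lower toxicity in this test and lower numbers for higher toxicity in this test), compound 1 gives > 100000 nM, which is a limit of the test rather than a number.
Compound 2 `CC(C)(C)OC(=O)NC(=O)c1ccc(CN2C(=O)c3ccccc3S2(=O)=O)cc1`: in this assay compound 2 gives > 100000 nM, again a limit.
Compound 3 `COC(=O)N(Cc1ccco1)C(=O)c1ccc(CN2C(=O)c3ccccc3S2(=O)=O)cc1`: in this assay compound 3 gives > 100000 nM, also a limit.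

Compound 3 therefore stands exactly where the other two stand: all three values sit at the limit of > 100000 nM in this assay, at which 3 of the 3 values shown sit, and nothing separates them on the numbers shown. The two measured steps, a step that the two limits leave unreadable from compound 1 to compound 2 and a step that the two limits leave unreadable from compound 1 to compound 3, cannot be read in size; both of their ends are limits. They do show that exchanging the whole amine part, or putting a methoxycarbonyl group onto the amide-type nitrogen, left the read-out at the limit.

Compound 4 `CC(C)(C)OC(=O)N(Cc1ccco1)C(=O)c1ccc(CN2C(=O)c3ccccc3S2(=O)=O)cc1` differs from compound 3 by tert-butyl in place of methyl on an oxygen next to a carbonyl group. Among the measured compounds shown here, no measured step touches this particular exchange. The compounds that share its core all remained at the limit after larger changes than this one, so the expectation is that compound 4 stays there as well, and the step that the limit leaves unreadable from compound 3 to compound 4 is expected to show no change beyond the scatter. For compound 4 the estimate in this assay is 150000 nM, with a range from 60000 nM to 500000 nM, most likely reported again only as a limit.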

Compound 4, concentration lethal to 50% of the cells: > 100000 nM
Compound 4 gave a limit, no number; the forecaster's own chance of this, stated with the estimate: 85%; the middle value is on the limit's open side.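

In this assay compound 4 gives > 100000 nM as a limit, not a number. With compound 1, compound 2, compound 3 and compound 4 all reported only as limits, none of the steps joining compound 4 to the other three can be read in size. The compounds shown leave open how far each lies beyond the limit, and whether any change to the shared core would give a readable value.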